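The compounds below may be only part of what the source reports. "The series", "measured", "known", "first", "only" and "open" are said of these compounds alone.

Compound 1, whose structure is `CCCCc1nc(C(C)C)c(CC(=O)OCC(F)(F)F)c(=O)n1Cc1ccc(-c2ccccc2-c2noc(=O)[nH]2)cc1`, is the starting point here. In an ADME assay on microsomes from liver (Mus musculus) for metabolic stability, with a stated time of 30 min (on this read-out lower numbers stand for a less stable compound and higher numbers for a more stable compound), compound 1 gives "not determined" (no result reported), so no single number stands for it. Two related compounds sharing the same core have been measured: compound 2, with structure `CCCCc1nc(C)c(CC(=O)OCC(C)C)c(=O)n1Cc1ccc(-c2ccccc2-c2noc(=O)[nH]2)cc1`, gives 7.7% in this assay, and compound 3, with structure `CCCCc1nc(C(C)(C)C)c(CC(=O)OCC)c(=O)n1Cc1ccc(-c2ccccc2-c2noc(=O)[nH]2)cc1`, gives 14%. These two values lie within the usual scatter of each other, and both are low. Compound 4, with structure `CCCCc1nc(C(C)C)c(C(C)C(=O)OCC)c(=O)n1Cc1ccc(-c2ccccc2-c2noc(=O)[nH]2)cc1`, differs from compound 1 in one place: 1-(ethoxycarbonyl)ethyl in place of ((2,2,2-trifluoroethoxy)carbonyl)methyl on an aromatic carbon. Given that compounds 2 and 3 both sit low in this assay, compound 4 is expected to sit low as well, and its estimated value is 15%, within a range of 4% to 40%.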

Compound 4, percent of the compound remaining: 28%
The estimate for compound 4 lay 13 percentage points below the measured number, within the range that was stated.
By their numbers in this assay, from the lowest: compounds 2 and 3 (each within the scatter of the next); then compound 4.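

Compound 1 gives "not determined" (no result reported) in this assay so no step to compound 4 can be read, and nothing shown here explains the result. From the compounds shown here alone, what the swap to 1-(ethoxycarbonyl)ethyl alone does to the percent remaining stays open.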